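The compounds below may be only part of what the source reports. "The series", "measured", "known", "first", "only" and "open" are said of these compounds alone.

Two ureas were tested in an ADME assay on the whole organism with Oryza sativa as the target, tested at 1 uM; on this read-out lower numbers stand for a stronger effect and higher numbers for a weaker effect at the one concentration tested. Compound 1, `CCc1ccccc1NC(=O)N[C@@H](C)c1ccccc1`, gives 100% in this assay. Compound 2, `C[C@@H](NC(=O)Nc1ccccc1C(F)(F)F)c1ccccc1`, gives 95% in this assay. These two numbers lie within the scatter of each other, so compound 2 cannot be set apart from compound 1: both stand at the weak end of the read-out, and neither can be called stronger or weaker than the other.

Compound 3, `C[C@H](NC(=O)Nc1ccccc1C(F)(F)F)c1ccccc1`, has not yet been measured in this assay. Its relation to compound 2 is the two compounds have the same atoms and bonds and differ only in configuration as drawn: 1 of 1 stereo elements differ; a stereocentre at a saturated chain carbon is drawn R in compound 2 and S in compound 3. Going by the values given here, no measured pair in this set shows what such a change in configuration does, so the expectation rests only on compound 2.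

Compound 3 is expected to give about 97%, with a likely range from 85% to 105%. The expected step, a number 2 percentage points higher from compound 2 to compound 3 (within the scatter), is none beyond the scatter, because compound 2 already gives 95% and the read-out has little room to move upward.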

Compound 3, a percentage reported as activity, at one concentration (the size of the read-out at that concentration, not a potency): 98%
Compound 3: the middle estimate sits 1 percentage points below what was measured; low and high end bracket the measured number.
By their numbers in this assay, from the lowest: compounds 2, 3 and 1 (each within the scatter of the next).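

Turning the stereocentre at the saturated chain carbon from R to S gives a number 3 percentage points higher from compound 2 to compound 3 (within the scatter), so the drawn configuration does not set these two compounds apart in this assay, and the comparison isolates that single change: the fact that compounds 2 and 3 differ only in the configuration as drawn. A second single change can now be read as well: trifluoromethyl in place of ethyl on an aromatic carbon gives a number 2 percentage points lower from compound 1 to compound 3 (within the scatter). Neither change moves the read-out beyond the scatter, and all three ureas stay at the weak end of it.

The compounds shown therefore leave open which change, if any, would move the read-out at all. Whether an amine, a carboxylic acid or a longer chain in place of trifluoromethyl would give a clearly lower number remains unsettled.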